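Methoxy in place of methyl on two different cores

The source may hold more compounds than are shown below. What is called first, only, known or untested is meant among the compounds shown, and "the series" means these compounds.

Measured so far in a physicochemical assay for lipophilicity, measured as octanol-water partition; on this read-out higher numbers stand for higher lipophilicity and lower numbers for lower lipophilicity:
compound 1 `Cc1ccc2c(c1)[n+]([O-])c(C#N)c(-c1ccco1)[n+]2[O-]`: 0.845
compound 2 `COc1ccc2c(c1)[n+]([O-])c(C#N)c(-c1ccco1)[n+]2[O-]`: 0.354
compound 3 `Cc1ccc(-c2c(C#N)[n+]([O-])c3cc(Cl)c(Cl)cc3[n+]2[O-])cc1`: 3.1

Compound 1 and compound 2 share a core and differ only by methoxy in place of methyl on an aromatic carbon. The step is a number 0.49 log units lower from compound 1 to compound 2 (beyond the scatter), a modest lowering and beyond the scatter.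

Compound 3 carries a different core and stands highest of the three in this assay, beyond the scatter from both compound 1 and compound 2. How the core of compound 3 differs from that of compound 1 is not broken down here.

Compound 4 `COc1ccc(-c2c(C#N)[n+]([O-])c3cc(Cl)c(Cl)cc3[n+]2[O-])cc1` is not yet measured. It differs from compound 3 by methoxy in place of methyl on an aromatic carbon. Within the data shown here, this is the same kind of change as the one from compound 1 to compound 2, but not the same: there the methoxy sits on a ring that is part of a fused or bridged system of two rings, meta to a fused ring and para to a fused ring, whereas here it sits para to a large group on a ring of carbon only.

Among the measured compounds shown here, with only the one earlier step to go on, the expected step is a number 0.50 log units lower from compound 3 to compound 4 (beyond the scatter), resting on compound 1 and compound 2 and their step of a number 0.49 log units lower from compound 1 to compound 2 (beyond the scatter). Compound 4 is therefore estimated at 2.6, expected between 2.2 and 3.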

Compound 4, partition coefficient: 2.33
Compound 4: the middle estimate sits 0.27 log units above what was measured, and the stated range covers the measured number.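

In this assay, methoxy in place of methyl again goes with a lower number, a number 0.77 log units lower from compound 3 to compound 4 (beyond the scatter), in the same direction as a number 0.49 log units lower from compound 1 to compound 2 (beyond the scatter), so the direction of the change holds on both cores, although the methoxy sits on a different kind of ring in each pair. Two pairs show this direction on these two cores only: they do not fix a size for the step, and they do not say that it would hold on a further core or at another place on the ring. Nothing available here accounts for the size of the step on either core.

The compounds shown leave open whether other groups in place of the methyl of the 4-methylphenyl ring, such as an amine, a carboxylic acid or a longer chain, would move this assay in the same direction. They also leave open how the methoxy step behaves on a core other than these two.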